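One Aryl Group Exchanged Beside a Carboxylic Acid

The source may hold more compounds than are shown below. What is called first, only, known or untested is meant among the compounds shown, and "the series" means these compounds.

Compound 1 `Cc1nn(-c2nc(-c3ccc(Cl)c(Cl)c3)c(SC(C)C)s2)c(C(=O)O)c1-c1cccc(Cl)c1C` was tested in a functional assay on BJAB cells (Homo sapiens) for antiproliferative activity, with a stated time of 4 days (on this read-out higher numbers stand for an effect only at larger amounts of compound and lower numbers for an effect already at smaller amounts), where compound 1 gives 5100 nM. Going by the values given here, that is the lowest of the two numbers known here: compound 2 `COC(=O)c1c(Cc2ccccc2[N+](=O)[O-])c(C)nn1-c1nc(-c2ccc(Cl)c(Cl)c2)c(SC(C)C)s1` gives 93000 nM in this assay, a clearly higher number that lies beyond the usual scatter. Compound 3 `Cc1c(-c2cc(Cl)cc(Cl)c2)c(C(=O)O)nn1-c1nc(-c2ccncc2)c(SC(C)C)s1` was reported as "not active" (no number reported) in this assay, without a number. Compound 4 `Cc1cc(C#N)cc(-c2c(C)nn(-c3nc(-c4ccc(Cl)c(Cl)c4)c(SC(C)C)s3)c2C(=O)O)c1` differs from compound 1 in one place: 3-cyano-5-methylphenyl in place of 3-chloro-2-methylphenyl on an aromatic carbon. Among the compounds with values here, no measured pair shows what this exchange does, so the expectation rests on compound 1 alone. The step of a 1.6-fold higher number from compound 1 to compound 4 (0.20 log units; within the scatter) is expected to be small, toward a somewhat higher number, at the edge of the scatter. Compound 4 is therefore estimated at 8000 nM, within a range from 2500 nM to 25000 nM.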

Compound 4, half-maximal effective concentration: 4800 nM
Estimate against measurement, compound 4: 1.7-fold (0.22 log units) above; the measured number falls inside the stated range.
By their numbers in this assay, from the lowest: compounds 4 and 1 (each within the scatter of the next); then compound 2.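

The exchange of 3-chloro-2-methylphenyl for 3-cyano-5-methylphenyl gives a 1.1-fold lower number from compound 1 to compound 4 (0.03 log units; within the scatter) in this assay, so this read-out does not separate the two compounds. At this position, next to the ring atom that bears a carboxy group, an aryl group carrying a nitrile is therefore compatible with a measurable number. No measurement on hand accounts for this match.

The exchange alters both the groups on the aryl ring and where they sit, and the compounds shown cannot separate these contributions. On these data alone, how an amine on that ring, or cyclohexyl in its place, would read also remains open.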